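Trifluoromethyl in place of fluoro on compound 1

This account rests on a few compounds, and the source may have more. Where it says the series, first, only, none or still open, it means among the compounds named here.

In an ADME assay on L02 cells (Homo sapiens) for cytotoxicity, read by MTT assay, with a stated time of 24 h (a higher number here means a weaker inhibitor, a lower number a stronger inhibitor), compound 1 (`O=C1/C(=C/c2cccnc2)CN(S(=O)(=O)c2ccc([N+](=O)[O-])cc2)C/C1=C\c1ccccc1F`) gives > 20000 nM as its reading, which is a limit of the assay and not a number. Its close relative compound 2 (`O=C1/C(=C/c2cccnc2)CN(S(=O)(=O)c2ccc(F)cc2)C/C1=C\c1ccccc1F`) gives 15600 nM as a true measured number in this assay and so offers a nearby reference point.

Compound 3 (`O=C1/C(=C/c2cccnc2)CN(S(=O)(=O)c2ccc([N+](=O)[O-])cc2)C/C1=C\c1ccccc1C(F)(F)F`) keeps the core of compound 1 and changes one group (trifluoromethyl in place of fluoro on an aromatic carbon) by putting trifluoromethyl in place of fluoro on an aromatic carbon, which turns 2-fluorophenyl into 2-(trifluoromethyl)phenyl.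

Among the measured compounds shown here, the only measured step is an at least 1.2-fold lower number from compound 1 to compound 2 (0.10 log units; that floor lies within the scatter) and it puts fluoro in place of nitro on an aromatic carbon, not the group changing here. It therefore bears on this change only loosely and gives no reason to expect a step beyond the scatter in this assay here.

The expected step is a step that the limit leaves unreadable from compound 1 to compound 3 and it is estimated to stay within the scatter.

For compound 3 the estimated value is 22000 nM with an expected range from 11000 nM to 45000 nM and the reading may again be only a limit.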

Compound 3, half-maximal inhibitory concentration: 15700 nM
Compound 3: middle estimate off by 1.4-fold (0.15 log units), on the high side, within the range that was stated.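

Compound 1 reads > 20000 nM in this assay, which is a limit of the assay and not a number. Among the compounds shown here, the earlier step changed the nitro group, whereas this one is the first to test the aromatic carbon ortho to a large group: trifluoromethyl in place of fluoro gives an at least 1.2-fold lower number from compound 1 to compound 3 (0.10 log units; that floor lies within the scatter), and compound 3 gives a true measured number. That step can be read only as a floor, because its starting point is a limit: the limit of > 20000 nM in this assay, at which 1 of the 3 values shown sits.

From the compounds shown here alone, how large the change from 2-fluorophenyl to 2-(trifluoromethyl)phenyl really is remains open, as the true value of compound 1 is unknown. Also open, going by these compounds, is how this cytotoxicity reading would respond to an amine or a carboxylic acid on that same aromatic carbon.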